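A few compounds are considered here, and "the series" means these few. Any claim that something is new, unique, unknown or untested is made for them only; others in the source may bear on it.

Measured in an ADME assay for permeability, using PAMPA; a higher number here means that the compound crosses the layer faster, a lower number that the compound crosses the layer more slowly
- compound 1 `O=C(Nc1ccc([N+](=O)[O-])cc1)c1cc(Cl)ccc1O` gives 127 10^-6 cm/s
- compound 2 `O=C(Nc1ccc(Cl)cc1)c1cc(Cl)ccc1O` gives 297 10^-6 cm/s

Compound 2 holds the higher of the two numbers, and the gap to compound 1 lies beyond the scatter. Unmeasured compound 3 `COc1ccc(NC(=O)c2cc(Cl)ccc2O)cc1` differs from compound 2 by methoxy in place of chloro on an aromatic carbon in words, methoxy in place of chloro on an aromatic carbon, para to a large group. For the measured compounds named here, one measured step bears on this place, the modest 2.3-fold higher number from compound 1 to compound 2 (0.37 log units; beyond the scatter) for chloro in place of nitro. On that single step, a small move to a lower number is expected in this assay and it may stay within the scatter. The expected step is a 1.5-fold lower number from compound 2 to compound 3 (0.17 log units; within the scatter) overall. Compound 3 is estimated at 200 10^-6 cm/s with an expected range from 100 10^-6 cm/s to 380 10^-6 cm/s for now.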

Compound 3, apparent permeability in the ADME assay: 81 10^-6 cm/s
For compound 3 the middle estimate is 2.5-fold (0.39 log units) above the measured one; measured number below the stated range.
By their numbers in the ADME assay, from the lowest: compounds 3 and 1 (each within the scatter of the next); then compound 2.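

In the ADME assay, methoxy in place of chloro on this aromatic carbon gives a 3.7-fold lower number from compound 2 to compound 3 (0.56 log units; beyond the scatter), while methoxy in place of nitro gives a 1.6-fold lower number from compound 1 to compound 3 (0.20 log units; within the scatter), so only chloro stands apart among these three groups. In a physicochemical assay for solubility (on this read-out lower numbers stand for lower solubility and higher numbers for higher solubility), methoxy in place of chloro gives an at least 2.8-fold higher number from compound 2 to compound 3 (0.44 log units; beyond the scatter), so this pair moves in opposite directions on the two read-outs. In the physicochemical assay, compound 2 gives < 1 ug/mL, which is a limit of the assay and not a number. In the physicochemical assay, compound 3 gives 2.8 ug/mL.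

Open, going by these compounds, is whether an amine or a carboxylic acid at this place would show the same opposite movement on the ADME assay and the physicochemical assay.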